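The compounds below may be only part of what the source reports. "The series", "measured", "known", "first", "only" and "open" are said of these compounds alone.

Measured compounds and their values in an ADME assay for permeability, using PAMPA, with a stated time of 30 min, at pH 7.4; a lower number here means that the compound crosses the layer more slowly, a higher number that the compound crosses the layer faster:
compound 1, `CC(C)Cc1ccc2c(NCCCNCc3ccco3)ccnc2c1`: 23 10^-6 cm/s
compound 2, `COc1ccc(F)cc1CNCCCNc1ccnc2cc(C3CCCCC3)ccc12`: 23 10^-6 cm/s
compound 3, `COc1cccc(CNCCCNc2ccnc3cc(-c4ccc(C(F)(F)F)cc4)ccc23)c1O`: 237 10^-6 cm/s

Compound 2 stands level with compound 1 at the digits given, and the two together are the lowest of the three numbers in this assay; the gap between compound 2 and compound 1 lies within the usual scatter, so no order can be read between them. Compound 3 lies furthest from compound 2, with a markedly higher number, which is beyond the scatter. Compound 3 differs from compound 2 in more than one place, so nothing more than what the two values show can be said of that pair.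

Compound 4, `COc1ccc(F)cc1CNCCCNc1ccnc2cc(Cc3ccc(F)cc3)ccc12`, has not yet been measured in this assay. It differs from compound 2 in one place: 4-fluorobenzyl in place of cyclohexyl on an aromatic carbon. Within the data shown here, no step between measured compounds isolates this change. The account therefore treats compound 4 with caution: the number is expected to lie above that of compound 2, but the expected step of a 1.7-fold higher number from compound 2 to compound 4 (0.24 log units; within the scatter) is small and may fall within the scatter. Compound 4 is estimated at 40 10^-6 cm/s, with a range from 15 10^-6 cm/s to 120 10^-6 cm/s.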

Compound 4, apparent permeability: 23 10^-6 cm/s
Estimate against measurement, compound 4: 1.7-fold (0.24 log units) above, and the stated range covers the measured number.
By their numbers in this assay, from the lowest: compounds 1, 2 and 4 (each within the scatter of the next); then compound 3.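

Among these compounds, compound 4 supplies the first comparison at this aromatic carbon, meta to a fused ring and para to a fused ring, that changes one place only: in this assay, 4-fluorobenzyl in place of cyclohexyl gives no change at the digits printed from compound 2 to compound 4 (within the scatter). Among the compounds shown here, in this one pair, then, a six-membered non-aromatic ring of carbon only and a fluorine-bearing group with a six-membered aromatic ring of carbon only read alike, something the earlier compounds, each differing from compound 2 in more than one place, could not show. Nothing on hand offers a reason for this outcome.

For the compounds shown here, still open is whether the number of compound 3, 237 10^-6 cm/s, belongs to the group it carries in this place or to the other place in which it differs from compound 2, as no one-place step separates the two. Also open, on these data alone, is how this assay would read with an amine, a carboxylic acid or a longer alkyl chain at this aromatic carbon in place of cyclohexyl or 4-fluorobenzyl.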